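This account rests on a few compounds, and the source may have more. Where it says the series, first, only, none or still open, it means among the compounds named here.

Measured so far in a functional assay on the whole organism with Rattus norvegicus as the target; a higher number here means that more compound is needed for the effect, a lower number that less compound is needed:

Compound 1, `CCCCCCc1ccc2nc(N)sc2c1`, gives 7 mg/kg.
Compound 2, `CCCCCCCc1ccc2nc(N)sc2c1`, gives > 10 mg/kg, which is a limit of the assay and not a number.
Compound 3, `Cn1c(=N)sc2cc(OC(F)(F)F)ccc21`, gives 5 mg/kg.

In this assay the step from compound 1 to compound 2 is an at least 1.4-fold higher number from compound 1 to compound 2 (0.15 log units; that floor lies within the scatter); the change is methyl in place of hydrogen on a saturated chain carbon, six bonds along the chain from an aromatic carbon. That the step has only a floor rests on (the limit of > 10 mg/kg in this assay, at which 1 of the 3 values shown sits). Compound 3 differs from compound 1 in its core, and the difference between the two cores is not broken down here; the value of compound 3 and that of compound 1 lie within the scatter of each other.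

Compound 4, `CCn1c(=N)sc2cc(OC(F)(F)F)ccc21`, is not yet measured. It differs from compound 3 by methyl in place of hydrogen on a saturated chain carbon bound to an aromatic nitrogen. This is the same kind of change as that from compound 1 to compound 2, but the place differs: there the added methyl sits on a saturated chain carbon, six bonds along the chain from an aromatic carbon, here on a saturated chain carbon bound to an aromatic nitrogen.

From compound 3 to compound 4 a step of a 1.4-fold higher number from compound 3 to compound 4 (0.15 log units; within the scatter) is expected, on the ground of the measured step of an at least 1.4-fold higher number from compound 1 to compound 2 (0.15 log units; that floor lies within the scatter). For compound 4 a value of 7 mg/kg is estimated, expected to lie between 3.5 mg/kg and 14 mg/kg.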

Compound 4, dose for half-maximal effect: 5 mg/kg
Compound 4: middle estimate off by 1.4-fold (0.15 log units), on the high side; the range from low to high includes it.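

In this assay, the added methyl on the saturated chain carbon bound to an aromatic nitrogen gives no change at the digits printed from compound 3 to compound 4 (within the scatter), so on the core of compound 3 going from methyl to ethyl leaves the dose as it was. This single result neither shows that the change carries over from one core to the other nor shows that it fails to, since the earlier step has only a floor: the same change on two cores in this assay, an at least 1.4-fold higher number (0.15 log units; that floor lies within the scatter) from compound 1 to compound 2 and no change at the digits printed (within the scatter) from compound 3 to compound 4; the limit leaves it open whether they differ

Compound 2 gives > 10 mg/kg, which is a limit of the assay and not a number, and the two steps also put the methyl in different places, so they offer no general rule for this change.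

The compounds shown leave open how the dose would respond on the core of compound 3 to a longer chain such as propyl or butyl. They also leave open what a chain carrying an amine or a carboxylic acid would do there.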